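Moving a fluorine on the outer ring of compound 2

This account rests on a few compounds, and the source may have more. Where it says the series, first, only, none or still open, it means among the compounds named here.

Among the measured compounds shown here, in a functional assay on a cell-free system (Platelet, plasma, Homo sapiens) for inhibition (a lower number here means a stronger inhibitor, a higher number a weaker inhibitor), compound 1 (`O=C(Nc1cccc(OCc2ccc(F)cc2)c1)C1CCNCC1`) gives 36000 nM, the only number so far. Compound 2 (`O=C(Nc1cccc(OCc2ccc(-c3cc(F)ccc3F)cc2)c1)C1CCNCC1`) has no number to place beside it, and its entry reads "not determined" (no result reported). Compound 3 is `O=C(Nc1cccc(OCc2ccc(-c3cc(F)cc(F)c3)cc2)c1)C1CCNCC1`. The change is 3,5-difluorophenyl in place of 2,5-difluorophenyl on an aromatic carbon, on an aromatic carbon, para to a large group. For the measured compounds named here, no measured step exists to size this swap, so no shift beyond the scatter is expected in this assay, in either direction. The expected level rests only on compound 1 at 36000 nM. The estimate for compound 3 is 20000 nM, with an expected range of 5000 nM to 80000 nM.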

Compound 3, half-maximal inhibitory concentration: 17000 nM
Compound 3: middle estimate off by 1.2-fold (0.07 log units), on the high side; low and high end bracket the measured number.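

In this assay, among the compounds shown here, 3,5-difluorophenyl in place of fluoro on this aromatic carbon gives a 2.1-fold lower number from compound 1 to compound 3 (0.33 log units; beyond the scatter), the first sized change, and a modest gain at this position. With no number for compound 2, the move from 2,5-difluorophenyl to 3,5-difluorophenyl cannot be read. Nothing on hand accounts for the step.

Still open, as far as these compounds go, is whether an unsubstituted phenyl at this position would hold the gain. Also open, from the compounds shown here alone, is how an amine or a carboxylic acid on the outer ring would shift the number.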